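Replacing the 4-methylphenyl group of compound 3

This account rests on a few compounds, and the source may have more. Where it says the series, first, only, none or still open, it means among the compounds named here.

Compound 1 `O=C(Nc1cccc(F)c1)c1cc(=O)[nH]c2cc(Br)ccc12`: 8900 nM
Compound 2 `O=C(Nc1cccc(F)c1)c1cc(=O)[nH]c2cc(-c3ccccc3F)ccc12`: > 20000 nM, a limit
Compound 3 `Cc1ccc(-c2ccc3c(C(=O)Nc4cccc(F)c4)cc(=O)[nH]c3c2)cc1`: > 20000 nM, a limit

These results come from a functional assay on KYSE-70 cells for antiproliferative activity against KYSE-70 cell line (Homo sapiens), read by MTT assay, with a stated time of 72 h; a lower number here means a stronger inhibitor, a higher number a weaker inhibitor. Compound 3 has no exact number and stands only at the limit of > 20000 nM in this assay, at which 2 of the 3 values shown sit. Compound 4 `O=C(Nc1cccc(F)c1)c1cc(=O)[nH]c2cc(C3=CCOCC3)ccc12` differs from it as follows: a group of 6 heavy atoms (5 carbon, 1 oxygen; one six-membered non-aromatic ring with 1 hetero atom) in place of a group of 7 heavy atoms (7 carbon; one six-membered aromatic ring of carbon only), on an aromatic carbon. Among the compounds with values here, two measured steps bear on this change, an at least 2.2-fold higher number from compound 1 to compound 2 (0.35 log units; beyond the scatter) and an at least 2.2-fold higher number from compound 1 to compound 3 (0.35 log units; beyond the scatter). Both lie beyond the scatter and both introduce an aromatic ring in place of bromo, whereas compound 4 carries a non-aromatic ring. The remaining step, a step that the two limits leave unreadable from compound 2 to compound 3, gives no size. A modest move toward a lower number is therefore expected, stated as an at least 1.3-fold lower number from compound 3 to compound 4 (0.12 log units; that floor lies within the scatter). For compound 4 the estimated value is 15000 nM, with an expected range of 6000 nM to 30000 nM.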

Compound 4, half-maximal inhibitory concentration: 10500 nM
Compound 4: middle estimate off by 1.4-fold (0.15 log units), on the high side, within the range that was stated.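

Compound 2 and compound 3 remain limits, not exact numbers, in this assay: the limit of > 20000 nM in this assay, at which 2 of the 4 values shown sit. At this position the non-aromatic ring gives a readable value, with an at least 1.9-fold lower number from compound 3 to compound 4 (0.27 log units; that floor lies within the scatter) and an at least 1.9-fold lower number from compound 2 to compound 4 (0.27 log units; that floor lies within the scatter), though the floor of each step lies within the scatter. Against bromo it shows a 1.2-fold higher number from compound 1 to compound 4 (0.07 log units; within the scatter), so the ring and bromine cannot be told apart here, whereas the aromatic rings of compound 2 and compound 3 moved beyond the scatter.

The compounds shown do not separate the part played by the ring oxygen from that of the double bond. On these data alone, how a saturated ring, an amine or a carboxylic acid would read at this position stays open.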